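Removing a methyl from an oxygen: what to expect

The source may hold more compounds than are shown below. What is called first, only, known or untested is meant among the compounds shown, and "the series" means these compounds.

In a functional assay on MDA-MB-468 cells (Homo sapiens) for cytotoxicity, read by sulforhodamine B assay, with a stated time of 48 h, tested at 100 nM (on this read-out lower numbers stand for a stronger effect and higher numbers for a weaker effect at the one concentration tested), compound 1 `Cc1cc(O)cc(-c2nn(CC#N)cc2-c2ccnc(-c3ccc(Oc4ccccc4)cc3)c2)c1` gives 88%. Compound 2 `COc1cc(C)cc(-c2nn(CC#N)cc2-c2ccnc(-c3ccc(N(C)C)cc3)c2)c1` gives -18% in this assay, the lowest of the two numbers shown, and the value of compound 1 sits higher by a gap beyond the usual scatter, so compound 2 shows the stronger effect at the one concentration tested. Compound 1 and compound 2 differ from each other in more than one place, so their two values say only that much and nothing about any single change.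

Compound 3 `Cc1cc(O)cc(-c2nn(CC#N)cc2-c2ccnc(-c3ccc(N(C)C)cc3)c2)c1` is compound 2 with one change: hydrogen in place of methyl on an oxygen on an aromatic ring. Among the compounds with values here, no pair of measured compounds differs only in this way, so there is no measured step to lean on; compound 1 also carries the hydroxy, but it differs from compound 3 elsewhere as well.

Within the data shown here, with no measured step for this change, the expected step in this assay is a number 13 percentage points higher from compound 2 to compound 3 (beyond the scatter), a shift expected to stay within the scatter in either direction. Compound 3 is therefore estimated at -5% in this assay, with an expected range from -35% to 40%.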

Compound 3, a percentage reported as activity, at one concentration (the size of the read-out at that concentration, not a potency): 77%
Compound 3: middle estimate off by 82 percentage points, on the low side, outside the stated range (above it).
By their numbers in this assay, from the lowest: compound 2; then compound 3; then compound 1.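

In this assay, the step of hydrogen in place of methyl on an oxygen on an aromatic ring is now measured on its own: the readout is a number 95 percentage points higher from compound 2 to compound 3 (beyond the scatter) and is rated large, meaning a much weaker effect at the one concentration tested, so this small methoxy to hydroxy change matters greatly at this position. Within the data shown here, with the hydroxy held constant, dimethylamino in place of phenoxy gives a number 11 percentage points lower from compound 1 to compound 3 (beyond the scatter) and is rated modest, so the two compounds that carry the hydroxy both sit at the weak end of this read-out, whichever of these two groups they bear, and the strong effect appears only in compound 2, the one compound with the methoxy. Nothing in the data shown accounts for why losing this one methyl has so large an effect.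

On these data alone, it remains open whether a longer chain on the same oxygen, such as ethoxy, would keep the effect seen with methoxy, or whether an amine in place of the methoxy would lose it as the hydroxy does. As far as these compounds go, it is also open whether methoxy would give as large a step in a compound that carries phenoxy instead of dimethylamino.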